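Biphenyl Carbamate Oximes: Swapping Phenyl for Thiophene

The compounds below may be only part of what the source reports. "The series", "measured", "known", "first", "only" and "open" are said of these compounds alone.

Measured compounds:
- compound 1, `C/C(=N\OC(=O)Nc1ccccc1)c1ccc(-c2ccccc2)cc1`: 760 nM
- compound 2, `C/C(=N\OC(=O)Nc1cccc2ccccc12)c1ccc(-c2ccccc2)cc1`: 401 nM

In an assay for inhibition of Fatty-acid amide hydrolase 1 (Mus musculus), read by scintillation counting (a lower number here means a stronger inhibitor, a higher number a weaker inhibitor), compound 1 gives the higher of the two numbers, and compound 2 gives 401 nM, which lies within the scatter of it. Compound 3, `C/C(=N\OC(=O)Nc1ccccc1)c1ccc(-c2cccs2)cc1`, differs from compound 1 by thiophen-2-yl in place of phenyl on an aromatic carbon. For the measured compounds named here, no measured pair shows this change, so the direction of the step is not known from these data. Compound 3 is expected to give 700 nM, between 250 nM and 2000 nM, so that the step of a 1.1-fold lower number from compound 1 to compound 3 (0.04 log units; within the scatter) is expected to stay within the scatter.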

Compound 3, half-maximal inhibitory concentration: 200 nM
Compound 3: the middle estimate sits 3.5-fold (0.54 log units) above what was measured; the whole stated range lies above it.
By their numbers in this assay, from the lowest: compounds 3, 2 and 1 (each within the scatter of the next, the first and the last beyond it).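

In this assay, thiophen-2-yl in place of phenyl on an aromatic carbon gives a 3.8-fold lower number from compound 1 to compound 3 (0.58 log units; beyond the scatter), a modest step. For the compounds shown here, compounds 1 and 2 both carry phenyl at this place, para to a large group, so this is the first sign that the number responds to a change there, and that a five-membered aromatic ring with a sulfur atom is tolerated. Nothing available accounts for the size of this step.

As far as these compounds go, it remains open whether thiophen-3-yl, furan-2-yl or a pyridine ring would give a similar number here. From the compounds shown here alone, whether the same change would give a similar step on compound 2 also remains open.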